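An acetyl group takes the place of fluoro

The source may hold more compounds than are shown below. What is called first, only, known or untested is meant among the compounds shown, and "the series" means these compounds.

Compound 1 (`COc1ccc(N2CCN(C(=S)SCc3ccc4nc(N)nc(N)c4c3)CC2)cc1`), compound 2 (`Cc1ccccc1N1CCN(C(=S)SCc2ccc3nc(N)nc(N)c3c2)CC1`) and compound 3 (`Nc1nc(N)c2cc(CSC(=S)N3CCN(c4ccc(F)cc4)CC3)ccc2n1`) share one core and differ only in a single group on an aromatic ring. In a functional assay on HeLa cells (Homo sapiens) for antiproliferative activity, read by MTT assay, with a stated time of 72 h (on this read-out higher numbers stand for weaker inhibition and lower numbers for stronger inhibition), compound 1 gives 1660 nM while compound 3 gives 1840 nM on the same read-out. For compound 2 the record shows "not determined" (no result reported) and it therefore adds nothing to the comparison. Going by the values given here, compound 3 thus stands level with compound 1, the only other compound with a number.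

Compound 4 (`CC(=O)c1ccc(N2CCN(C(=S)SCc3ccc4nc(N)nc(N)c4c3)CC2)cc1`) follows from compound 3 with acetyl in place of fluoro on an aromatic carbon, para to a large group (acetyl in place of fluoro on an aromatic carbon). Among the compounds with values here, one measured step bears on this change: fluoro in place of methoxy on an aromatic carbon gave a 1.1-fold higher number from compound 1 to compound 3 (0.04 log units; within the scatter) and no more. Within the data shown here, no measured compound carries acetyl, so this single step is thin evidence for a larger and different group. A shift no larger than the scatter is therefore expected, in neither direction in particular, and the estimated change reads a 1.1-fold lower number from compound 3 to compound 4 (0.03 log units; within the scatter) for now. In this assay the estimate for compound 4 is 1700 nM with an expected range from 700 nM to 4000 nM until the measurement is known.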

Compound 4, half-maximal inhibitory concentration: 2040 nM
Beside the measured number, compound 4's estimate is 1.2-fold (0.08 log units) below it; the measured number falls inside the stated range.
By their numbers in this assay, from the lowest: compounds 1, 3 and 4 (each within the scatter of the next).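

In this assay, acetyl in place of fluoro gave a 1.1-fold higher number from compound 3 to compound 4 (0.04 log units; within the scatter) and acetyl in place of methoxy gave a 1.2-fold higher number from compound 1 to compound 4 (0.09 log units; within the scatter), so both steps stay within the scatter. The earlier compounds shown here had compared only methoxy and fluoro, whereas this result extends the comparison to a group with 3 heavy atoms, a double bond outside the aromatic ring and 1 hydrogen-bond acceptor, and on an aromatic carbon, para to a large group, the read-out still does not separate the three groups. Nothing available explains why these differences between the groups leave the numbers so close.

The compounds shown leave open whether this tolerance extends to groups of another kind at the same place, such as an amine, a carboxylic acid or a longer chain, any of which might move the number beyond the scatter. They also leave open whether the same three groups would stay this close in cells other than those of this assay or on a different position of the same aromatic ring.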